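Swapping the amide aryl group on a shared flavonol core

This account rests on a few compounds, and the source may have more. Where it says the series, first, only, none or still open, it means among the compounds named here.

Three analogues of one core have been tested for antiproliferative activity in a functional assay on MCF7 cells (Homo sapiens) for antiproliferative activity, read by CCK-8 assay, with a stated time of 72 h; on this read-out higher numbers stand for weaker inhibition and lower numbers for stronger inhibition. Compound 1 `Cc1ccccc1C(=O)Nc1cccc(-c2oc3cc(-c4ccc(F)cc4)ccc3c(=O)c2O)c1` gives 2280 nM. Compound 2 `Cc1cc(C)cc(C(=O)Nc2cccc(-c3oc4cc(-c5ccc(F)cc5)ccc4c(=O)c3O)c2)c1` gives 20400 nM, a weaker result; the step of an 8.9-fold higher number from compound 1 to compound 2 (0.95 log units; beyond the scatter) lies beyond the scatter. Compound 3 `O=C(Nc1cccc(-c2oc3cc(-c4ccc(F)cc4)ccc3c(=O)c2O)c1)c1ccc(Cl)nc1` gives 2890 nM, which stands second highest of the three numbers; the step of a 1.3-fold higher number from compound 1 to compound 3 (0.10 log units; within the scatter) is within the scatter, while the step of a 7.1-fold lower number from compound 2 to compound 3 (0.85 log units; beyond the scatter) is beyond it.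

Compound 4 `O=C(Nc1cccc(-c2oc3cc(-c4ccc(F)cc4)ccc3c(=O)c2O)c1)c1cc(F)cc(F)c1` has not been measured. It differs from compound 3 by 3,5-difluorophenyl in place of 6-chloropyridin-3-yl on a carbonyl carbon. The step most closely related is the move from compound 2 to compound 3, where a 3,5-dimethylphenyl group gave the highest number of the set and the 6-chloropyridin-3-yl group lowered it by a 7.1-fold lower number from compound 2 to compound 3 (0.85 log units; beyond the scatter). Compound 4 again carries a 3,5-disubstituted phenyl on the carbonyl carbon, so a modestly higher number is expected in this assay, estimated as a 2.1-fold higher number from compound 3 to compound 4 (0.32 log units; beyond the scatter). Compound 4 is therefore expected to give about 6000 nM, within a range from 2000 nM to 18000 nM.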

Compound 4, half-maximal inhibitory concentration: 2490 nM
Beside the measured number, compound 4's estimate is 2.4-fold (0.38 log units) above it; the range from low to high includes it.
By their numbers in this assay, from the lowest: compounds 1, 4 and 3 (each within the scatter of the next); then compound 2.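

In this assay the step of an 8.2-fold lower number from compound 2 to compound 4 (0.91 log units; beyond the scatter) shows that a 3,5-disubstituted phenyl on the carbonyl carbon does not by itself bring the high number of compound 2, since 3,5-difluorophenyl and 3,5-dimethylphenyl at the same place lie clearly apart. The steps of a 1.2-fold lower number from compound 3 to compound 4 (0.06 log units; within the scatter) and a 1.1-fold higher number from compound 1 to compound 4 (0.04 log units; within the scatter) both stay within the scatter, so 3,5-difluorophenyl joins 6-chloropyridin-3-yl and 2-methylphenyl as a group that this read-out does not separate, and among these four compounds only compound 2 stands apart. Nothing at hand accounts for the gap between the fluorine and methyl pairs.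

The compounds shown leave open whether the gap follows from both methyl groups together or from one alone, as a 3-methylphenyl group would test. They also leave open how a 3,5-dichlorophenyl or a 3,5-dimethoxyphenyl group on the carbonyl carbon would read here.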